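The source may hold more compounds than are shown below. What is called first, only, known or untested is meant among the compounds shown, and "the series" means these compounds.

Compound 1 `Cc1ccc(S(=O)(=O)Oc2ccccc2/C=C(\C#N)C(=O)Nc2nnc(Cc3ccccc3)s2)cc1`: 15%
Compound 2 `N#C/C(=C\c1ccccc1OS(=O)(=O)c1ccccc1[N+](=O)[O-])C(=O)Nc1nnc(Cc2ccccc2)s1`: 10%
Compound 3 `N#C/C(=C\c1ccccc1OS(=O)(=O)c1ccc(Cl)cc1)C(=O)Nc1nnc(Cc2ccccc2)s1`: 25%

In an ADME assay on HEK-293T cells (Homo sapiens) for inhibition, read by CCK-8 assay, with a stated time of 48 h, tested at 20 uM (a higher number here means more inhibition of growth at the concentration tested, a lower number less inhibition of growth), compound 3 gives 25%. Among the compounds with values here, that number lies within the scatter of the one for compound 1, with a number 10 percentage points higher from compound 1 to compound 3 (within the scatter), and beyond the scatter of the one for compound 2, with a number 15 percentage points higher from compound 2 to compound 3 (beyond the scatter).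

Compound 4 `N#C/C(=C\c1ccccc1OS(=O)(=O)c1ccc(Cl)cc1)C(=O)Nc1nnc(Cc2ccc(F)cc2)s1` carries fluoro in place of hydrogen on an aromatic carbon, benzyl to 4-fluorobenzyl: fluoro in place of hydrogen on an aromatic carbon.

Within the data shown here, no measured step touches the benzyl group. All three concern the group on the sulfonyl sulfur, so they bear only indirectly and give a rough size for changes in this series, the third being a number 5 percentage points lower from compound 1 to compound 2 (within the scatter). In this assay no step beyond the scatter is expected, and the estimated step is no change at the digits printed from compound 3 to compound 4 (within the scatter). Compound 4 is estimated at 25%, within an expected range of 10% to 45%.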

Compound 4, percent growth inhibition at one concentration: 6%
Estimate against measurement, compound 4: 19 percentage points above; the whole stated range lies above it.
By their numbers in this assay, from the lowest: compounds 4, 2, 1 and 3 (each within the scatter of the next, the first and the last beyond it).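

The benzyl end of the series is not inert: in this assay, benzyl to 4-fluorobenzyl gives a number 19 percentage points lower from compound 3 to compound 4 (beyond the scatter), the first step read at this position. One fluoro on the aromatic carbon here moves the number by a step of similar modest size to the largest on the sulfonyl side, a number 15 percentage points higher from compound 2 to compound 3 (beyond the scatter). No measurement on hand accounts for this step.

Open, from the compounds shown here alone, is whether the step is specific to fluoro, or whether a chloro, a methoxy or an amine at the same place, or a longer chain in place of benzyl, would give a similar number. Also open, going by these compounds, is whether the step holds with a sulfonyl group other than 4-chlorophenyl.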